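Methyl for hydrogen: compound 3 to compound 4

The source may hold more compounds than are shown below. What is called first, only, known or untested is meant among the compounds shown, and "the series" means these compounds.

Compound 3 `O=C1N/C(=N/c2csc(-c3ccc(Cl)cc3)c2)S/C1=C\c1ccccc1` carries a phenyl on the exocyclic double bond of the shared core. For the measured compounds named here, in a functional assay on MDA-MB-231 cells (Homo sapiens) for cytotoxicity, read by MTT assay, with a stated time of 72 h (on this read-out lower numbers stand for stronger inhibition and higher numbers for weaker inhibition), compound 3 gives 18000 nM, the only number among the three values shown. Compound 1 `Cc1ccc(-c2cc(/N=C3/NC(=O)CS3)cs2)cc1` lacks that phenyl-bearing double bond and carries a methyl on its six-membered ring. In this assay compound 1 gives > 50000 nM, a limit of the assay and not a number. Compound 2 `O=C1CS/C(=N\c2csc(-c3ccc(Cl)cc3)c2)N1` has chloro where compound 1 has methyl. In this assay compound 2 gives > 50000 nM, again a limit. The step that the two limits leave unreadable from compound 1 to compound 2 therefore cannot be read, both ends sitting at the limit of > 50000 nM in this assay, at which 2 of the 3 values shown sit.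

Compound 4 `Cc1ccc(/C=C2\S/C(=N\c3csc(-c4ccc(Cl)cc4)c3)NC2=O)cc1` differs from compound 3 by methyl in place of hydrogen on an aromatic carbon; read one bond further out, this is phenyl to 4-methylphenyl. Going by the values given here, no measured step touches this ring: the one measured step concerns the other six-membered ring and is unreadable. With nothing pointing either way, no step beyond the scatter is expected in this assay. Compound 4 is expected to give 18000 nM, between 6000 nM and 50000 nM. The expected step of no change at the digits printed from compound 3 to compound 4 (within the scatter) is thus close to none.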

Compound 4, half-maximal inhibitory concentration: 900 nM
Compound 4: middle estimate off by 20-fold (1.30 log units), on the high side; measured number outside the range, below it.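

In this assay, the outer phenyl on the exocyclic double bond proves sensitive to substitution: a single methyl, para to a large group, gives a 20-fold lower number from compound 3 to compound 4 (1.30 log units; beyond the scatter). This is the first readable substituent step in the series, and it shows that one added carbon at this place can shift the number well beyond the scatter; the only earlier step, chloro in place of methyl on the other six-membered ring, cannot be read, both of its ends being limits of the assay and not numbers: the limit of > 50000 nM in this assay, at which 2 of the 4 values shown sit.
Nothing shown bears on why so small a change has so large a step in this assay.

Open, from the compounds shown here alone, is whether the step belongs to methyl itself or to any group at this place, which an ethyl, a longer chain, a methoxy, an amine or a carboxylic acid on the same ring would begin to answer. Also open, going by these compounds, is whether the step persists when methyl replaces chloro on the other six-membered ring with the substituted double bond in place, and whether the same methyl at another place on the outer ring gives a step of similar size.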